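Chloro for Fluoro on the Aryl Ring of Compound 1

The source may report more compounds than this note shows. Statements on the series, on what has been measured and on what is new or still open speak of the compounds shown alone.

Compound 1 `O=C(NCc1cn(Cc2ccc(Cl)cc2)nn1)c1cn(-c2ccccc2)nc1-c1ccc(F)cc1` stands lowest of the two numbers in a functional assay on HeLa cells (Homo sapiens) for antiproliferative activity, read by sulforhodamine B assay, with a stated time of 48 h (a higher number here means a weaker inhibitor of growth, a lower number a stronger inhibitor of growth), where compound 1 gives 210 nM. Compound 2 `COc1cc(Cn2cc(CNC(=O)c3cn(-c4ccccc4)nc3-c3ccc(F)cc3)nn2)cc(OC)c1OC` gives 2100 nM in this assay, and the step of a 10-fold higher number from compound 1 to compound 2 (1.00 log units; beyond the scatter) concerns a different position of the shared core. Compound 3 `O=C(NCc1cn(Cc2ccc(Cl)cc2)nn1)c1cn(-c2ccccc2)nc1-c1ccc(Cl)cc1` differs from compound 1 by chloro in place of fluoro on an aromatic carbon. For the measured compounds named here, no measured step touches this position, so no change beyond the scatter is expected in this assay. The expected step of no change at the digits printed from compound 1 to compound 3 (within the scatter) is accordingly small. Compound 3 is estimated at 210 nM, with a range from 80 nM to 600 nM.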

Compound 3, concentration for 50% growth inhibition: 470 nM
Compound 3: middle estimate off by 2.2-fold (0.35 log units), on the low side; the range from low to high includes it.
By their numbers in this assay, from the lowest: compound 1; then compound 3; then compound 2.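

At this position, the step in this assay is a 2.2-fold higher number from compound 1 to compound 3 (0.35 log units; beyond the scatter) and shows that the 4-fluorophenyl group is not indifferent to a change of halogen, which the earlier step, made elsewhere on the shared core, could not show. Even this exchange of one heavy atom for another moves the number beyond the scatter. Nothing available explains the shift.

The compounds shown leave open how hydrogen, a methoxy group or an amine in this place would compare. They also leave open whether the same exchange has a similar effect when 3,4,5-trimethoxyphenyl replaces 4-chlorophenyl.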